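The compounds below may be only part of what the source reports. "The series", "measured", "known", "first", "only" and "open" are said of these compounds alone.

Measured so far in a physicochemical assay for solubility, with a stated time of 18 h, at pH 7.4; on this read-out higher numbers stand for higher solubility and lower numbers for lower solubility: compound 1 `Fc1ccc(Cc2ccc3c(NCCCNCc4ccco4)ccnc3c2)c(Cl)c1` gives 4200 nM. Compound 2 `c1coc(CNCCCNc2ccnc3cc(-c4cccc5ccccc45)ccc23)c1` gives 32000 nM. Compound 3 `COc1cccc(CNCCCNc2ccnc3cc(Cc4ccc(F)cc4Cl)ccc23)c1O` gives 4200 nM.

Compound 3 and compound 1 are the two lowest numbers of the three, level with each other at the digits reported. Their cores differ by 2-hydroxy-3-methoxyphenyl in place of furan-2-yl on a saturated chain carbon bound to an amine nitrogen; in this assay that change gave no change at the digits printed from compound 1 to compound 3 (within the scatter).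

Compound 4 `COc1cccc(CNCCCNc2ccnc3cc(-c4cccc5ccccc45)ccc23)c1O` is not yet measured in this assay. It differs from compound 3 by naphthalen-1-yl in place of 2-chloro-4-fluorobenzyl on an aromatic carbon. The same change, at a place described in identical words, was made once already: from compound 1 to compound 2 it gave a 7.6-fold higher number from compound 1 to compound 2 (0.88 log units; beyond the scatter), a shift of modest size but clearly beyond the scatter. It is therefore treated as the same change, seen a second time on a core that differs only by the part described above.

For compound 4 the expected step is a 7.6-fold higher number from compound 3 to compound 4 (0.88 log units; beyond the scatter). Within the data shown here, this expectation rests on the one measured instance of the change, a 7.6-fold higher number from compound 1 to compound 2 (0.88 log units; beyond the scatter), and on the observation that the core change itself left this read-out unmoved, no change at the digits printed from compound 1 to compound 3 (within the scatter). Compound 4 is accordingly estimated at 32000 nM, within a range from 12000 nM to 80000 nM.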

Compound 4, solubility: 32000 nM
For compound 4 middle estimate and measured number coincide at the digits printed; the measured number falls inside the stated range.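

In this assay, naphthalen-1-yl in place of 2-chloro-4-fluorobenzyl gave a 7.6-fold higher number from compound 3 to compound 4 (0.88 log units; beyond the scatter) on the core carrying 2-hydroxy-3-methoxyphenyl, the same size of step as a 7.6-fold higher number from compound 1 to compound 2 (0.88 log units; beyond the scatter) on the core carrying furan-2-yl. The reverse reading agrees: 2-hydroxy-3-methoxyphenyl in place of furan-2-yl gave no change at the digits printed from compound 2 to compound 4 (within the scatter) with naphthalen-1-yl present, as it gave no change at the digits printed from compound 1 to compound 3 (within the scatter) with 2-chloro-4-fluorobenzyl present, so across these four compounds the two changes behave independently and none goes against this. This is one pair on each of two closely related cores, so it shows transfer between these cores only, not a general rule for the series, and nothing available bears on why the step carries over.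

Still open, from the compounds shown here alone, is whether the step survives when an amine or a carboxylic acid takes the place of the furan-2-yl or 2-hydroxy-3-methoxyphenyl group. A longer chain between the shared core and that group is equally untested by the compounds shown here.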